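The source may report more compounds than this note shows. Statements on the series, on what has been measured and on what is new or still open speak of the compounds shown alone.

Compound 1 `C=C/C=C/[C@](C)(O)C/C=C/[C@H]1[C@H](O)CC(=O)[C@@H]1CC/C=C\CCC(=O)OC`: in a functional assay on the whole organism with Rattus norvegicus as the target (a higher number here means that more compound is needed for the effect, a lower number that less compound is needed), compound 1 gives 0.243 mg/kg.
Compound 2 `CCCCC(C)(O)C/C=C/[C@H]1[C@H](O)CC(=O)[C@@H]1CC/C=C\CCC(=O)OC`: in this assay compound 2 gives 0.049 mg/kg.
Compound 3 `COC(=O)CC/C=C\CC[C@H]1C(=O)C[C@@H](O)[C@@H]1/C=C/C[C@@](C)(O)/C=C/C(C)=C(C)C`: in this assay compound 3 gives only a limit of the assay, > 3.16 mg/kg, so its true number is not known.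

Compound 4 `C=C(C)/C=C/[C@](C)(O)C/C=C/[C@H]1[C@H](O)CC(=O)[C@@H]1CC/C=C\CCC(=O)OC` is not yet measured. It differs from compound 3 in one place: 1-methylethenyl in place of 1,2-dimethylprop-1-en-1-yl on a double-bonded chain carbon bound to a double-bonded chain carbon. This change cuts the group back toward the vinyl of compound 1, and the step that bears on it is an at least 13-fold higher number from compound 1 to compound 3 (1.11 log units; beyond the scatter), a large rise in dose when that group was enlarged. Undoing part of that enlargement is therefore expected to lower the number again, a step of about an at least 5.2-fold lower number from compound 3 to compound 4 (0.72 log units; beyond the scatter). Compound 4 is estimated at 0.6 mg/kg, within 0.15 mg/kg to 2.5 mg/kg.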

Compound 4, dose for half-maximal effect: 0.42 mg/kg
Compound 4: middle estimate off by 1.4-fold (0.15 log units), on the high side; measured number inside the range.
By their numbers in this assay, from the lowest: compound 2; then compounds 1 and 4 (each within the scatter of the next). At a limit, above all of these: compound 3.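

Methyl in place of hydrogen on this double-bonded chain carbon stays within the scatter a 1.7-fold higher number from compound 1 to compound 4 (0.24 log units; within the scatter), so a small branch here is tolerated in this assay. The jump in dose appears only with the larger 1,2-dimethylprop-1-en-1-yl group, and the step down from the limit held by compound 3 lies beyond the scatter an at least 7.5-fold lower number from compound 3 to compound 4 (0.87 log units; beyond the scatter). Even so, the unsaturated side chain still needs more compound than 1-hydroxy-1-methylpentyl an 8.6-fold higher number from compound 2 to compound 4 (0.93 log units; beyond the scatter).

From the compounds shown here alone, what an amine or a longer chain at this place would do remains open.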